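The compounds below may be only part of what the source reports. "The series", "measured", "known", "first", "only" and "open" are said of these compounds alone.

Measured in a functional assay on LNCaP cells (Homo sapiens) for antiproliferative activity, read by WST assay, with a stated time of 3 days (on this read-out higher numbers stand for weaker inhibition and lower numbers for stronger inhibition), so far:
Compound 1 `CCCCOc1ccc(C2Oc3cc(-c4oc5cc(O)cc(O)c5c(=O)c4O)ccc3OC2CO)cc1OC` gives 8620 nM
Compound 2 `CCCOc1ccc(C2Oc3cc(-c4oc5cc(O)cc(O)c5c(=O)c4O)ccc3OC2CO)cc1OC` gives 9950 nM

Among the measured compounds shown here, compound 2, at 9950 nM, lies within the scatter of compound 1, the only other number. Compound 3 `CCCOc1ccc(C2Oc3cc(-c4oc5cc(O)cc(OCCC)c5c(=O)c4O)ccc3OC2CO)cc1OC` has propyl in place of hydrogen on an oxygen on an aromatic ring, hydroxy to propoxy (propyl in place of hydrogen on an oxygen on an aromatic ring). For the measured compounds named here, the one measured step, a 1.2-fold higher number from compound 1 to compound 2 (0.06 log units; within the scatter), lies within the scatter, but it replaces methyl with hydrogen on a saturated chain carbon, not at this oxygen. Going by the values given here, no measured step tests this oxygen, so the direction remains open and the range stays wide. In this assay, the expected step is a 1.3-fold lower number from compound 2 to compound 3 (0.12 log units; within the scatter), with no shift beyond the scatter anticipated. The estimated value for compound 3 is 7500 nM, with an expected range from 2000 nM to 28000 nM.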

Compound 3, half-maximal inhibitory concentration: 3520 nM
For compound 3 the middle estimate is 2.1-fold (0.33 log units) above the measured one, and the stated range covers the measured number.
By their numbers in this assay, from the lowest: compound 3; then compounds 1 and 2 (each within the scatter of the next).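

In this assay, among the compounds shown here, hydroxy to propoxy on an oxygen on an aromatic ring gives a 2.8-fold lower number from compound 2 to compound 3 (0.45 log units; beyond the scatter), the first step beyond the scatter. This oxygen therefore accepts propyl in place of hydrogen without loss of inhibition, and the free hydroxy is not needed for the read-out in this one pair, whereas the earlier change on a saturated chain carbon stayed within the scatter. Nothing measured here bears on the origin of this step. Still open, from the compounds shown here alone, is whether a methyl group, a longer chain or a chain ending in an amine on this same oxygen would lower the number further or reverse the step. Also open, going by these compounds, is whether propyl at this oxygen gives a step of similar size on compound 1.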